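The source may hold more compounds than are shown below. What is called first, only, known or untested is meant among the compounds shown, and "the series" means these compounds.

Measured in a physicochemical assay for solubility; a higher number here means a more soluble compound, a lower number a less soluble compound:
- Compound 1 `O=C(Nc1ccccc1Cl)c1cc(Cl)ccc1O`: 5 ug/mL
- Compound 2 `O=C(Nc1c(Cl)cc([N+](=O)[O-])cc1Cl)c1cc(Cl)ccc1O`: 53 ug/mL
- Compound 3 `O=C(Nc1ccccc1C(F)(F)F)c1cc(Cl)ccc1O`: > 47 ug/mL, a limit of the assay

Of the two plain numbers, the lower belongs to compound 1 at 5 ug/mL, and compound 2 stands higher at 53 ug/mL. Compound 3 reports only a limit, > 47 ug/mL.

The unmeasured compound 4 `CC(=O)Nc1ccc(NC(=O)c2cc(Cl)ccc2O)c(Cl)c1` keeps the core of compound 1 and carries one change: acetamido in place of hydrogen on an aromatic carbon. Going by the values given here, no measured step brings in acetamido. Among the compounds with values here, the only one-place step available, trifluoromethyl in place of chloro on an aromatic carbon, gave an at least 9.4-fold higher number from compound 1 to compound 3 (0.97 log units; beyond the scatter) in this assay. That step lies beyond the scatter, but it replaces the chloro group that compound 4 keeps, so it bears on this change only loosely. Compound 2, at 53 ug/mL, also sits higher than compound 1, although it differs in more than one place. A modest move towards a higher number in this assay is therefore expected, smaller than the measured step, and the lower end of the range allows for no real change. The estimated step is a 2.4-fold higher number from compound 1 to compound 4 (0.38 log units; beyond the scatter). For compound 4 the estimated value is 12 ug/mL, with an expected range from 4 ug/mL to 40 ug/mL.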

Compound 4, solubility: 5.1 ug/mL
Estimate against measurement, compound 4: 2.4-fold (0.37 log units) above; the range from low to high includes it.
By their numbers in this assay, from the lowest: compounds 1 and 4 (each within the scatter of the next); then compound 2.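

In this assay, acetamido in place of hydrogen on an aromatic carbon, para to a large group and meta to a chloro group, gives a 1.0-fold higher number from compound 1 to compound 4 (0.01 log units; within the scatter) and so leaves the read-out within the scatter. Going by these compounds alone, this shows that the position takes a group of 4 heavy atoms, with a hydrogen-bond donor and a hydrogen-bond acceptor, without a step beyond the scatter, whereas the only earlier one-place step, an at least 9.4-fold higher number from compound 1 to compound 3 (0.97 log units; beyond the scatter), rests on a limit of the assay and replaces the chloro group that compound 4 keeps, so it did not speak to this position. Nothing among the values shown accounts for the absence of a step here.

The compounds shown leave open whether a different group at this position, such as an amine, a carboxylic acid or a longer chain, would also stay within the scatter of compound 1, and whether acetamido would behave in the same way at another place on the ring. They also leave open how acetamido would read alongside trifluoromethyl in place of the chloro group, since no compound shown carries both.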